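Hydroxypyrrolidine acid versus open-chain hydroxy amino acid on the benzyl arm

This account rests on a few compounds, and the source may have more. Where it says the series, first, only, none or still open, it means among the compounds named here.

Working notes on the series. For the measured compounds named here, compound 1 `COc1ccc(/C=C\c2cc(OC)c(OC)c(OC)c2)cc1OCc1ccc(CNC(C)(C)C(=O)O)cc1` is the only member with a readable number: in a functional assay on HepG2 cells (Homo sapiens) for antiproliferative activity, read by CCK-8 assay, with a stated time of 48 h (on this read-out lower numbers stand for stronger inhibition and higher numbers for weaker inhibition), compound 1 gives 6500 nM. Compound 2 `COc1ccc(/C=C\c2cc(OC)c(OC)c(OC)c2)cc1OCc1ccc(CN2C[C@H](O)C[C@@H]2C(=O)O)cc1` reaches only the assay limit, > 10000 nM in this assay. Compound 3 `COc1ccc(/C=C\c2cc(OC)c(OC)c(OC)c2)cc1OCc1ccc(CN[C@H](C(=O)O)[C@H](C)O)cc1` likewise gives only the limit > 10000 nM in this assay. The two measured steps from the open-chain acid are an at least 1.5-fold higher number from compound 1 to compound 2 (0.18 log units; that floor lies within the scatter) and an at least 1.5-fold higher number from compound 1 to compound 3 (0.18 log units; that floor lies within the scatter). The direct step that the two limits leave unreadable from compound 2 to compound 3 stays unreadable because of the limit of > 10000 nM in this assay, at which 2 of the 3 values shown sit.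

Compound 4 `COc1ccc(/C=C\c2cc(OC)c(OC)c(OC)c2)cc1OCc1ccc(CN[C@H](C(=O)O)[C@@H](C)O)cc1` differs from compound 2 in one place: (1-carboxy-2-hydroxypropyl)amino in place of 2-carboxy-4-hydroxypyrrolidin-1-yl on a saturated chain carbon bound to an aromatic carbon. Compound 3 carries the same entering group with the other configuration at one of its two defined stereocentres, and compound 3 sits at the limit. Going by the values given here, the only step that bears on compound 4 is therefore unreadable, and neither bound suggests a return to the range of compound 1. Compound 4 is expected to stay at or past the limit, so the step that the limit leaves unreadable from compound 2 to compound 4 is estimated as none that the assay can resolve. Compound 4 is expected at about 15000 nM, in the range 6000 nM to 40000 nM.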

Compound 4, half-maximal inhibitory concentration: > 10000 nM
Compound 4 ended at the assay's limit; the forecaster's own chance of this, stated with the estimate: 70%; the middle value lies beyond the limit too.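

In this assay compound 4 gives only a limit, > 10000 nM. For the compounds shown here, the one readable step is an at least 1.5-fold higher number from compound 1 to compound 4 (0.18 log units; that floor lies within the scatter), so the second configuration of the 1-carboxy-2-hydroxypropyl group on the amine nitrogen does not bring the series back to a readable number. The steps among compound 2, compound 3 and compound 4 cannot be read, and no order among these three can be stated: the limit of > 10000 nM in this assay, at which 3 of the 4 values shown sit.

How far each of these compounds lies past the limit stays open, and with it whether the changed stereocentre has any effect in this assay: the fact that compounds 3 and 4 differ only in the configuration as drawn. Also open, from the compounds shown here alone, is whether a methyl ester or a primary amide in place of the carboxylic acid of the 1-carboxy-1-methylethyl group would give a readable number.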